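The source may report more compounds than this note shows. Statements on the series, on what has been measured and on what is new or still open speak of the compounds shown alone.

Going by the values given here, in an ADME assay on HEK293 cells (Homo sapiens) for inhibition, read by MTT assay, with stated times of 18 h and 4 h (on this read-out lower numbers stand for stronger inhibition and higher numbers for weaker inhibition), compound 3 (`CCCCCCOP(=O)(O)OCCSC(=S)N1CCCCCC1`) gives 70500 nM, the only actual number among the three compounds measured. Compound 1 (`CCCCCCCCCCOP(=O)(O)OCCSC(=S)N1CCCC1`) reads > 100000 nM, which is a limit of the assay and not a number. Compound 2 (`CCCOP(=O)(O)OCCSC(=S)N1CCCC1`) reads > 100000 nM, again a limit. Among the compounds with values here, the one measured step, a step that the two limits leave unreadable from compound 1 to compound 2, therefore offers no usable size. Compound 4 (`CCCCCCOP(=O)(O)OCCSC(=S)N1CCCC1`) departs from compound 3 by pyrrolidin-1-yl in place of azepan-1-yl on a thiocarbonyl carbon, placing pyrrolidin-1-yl where azepan-1-yl stood on a thiocarbonyl carbon. Weaker inhibition is expected because compound 2 sits at > 100000 nM with that same pyrrolidin-1-yl. The expected change, modest in size, is a 2.1-fold higher number from compound 3 to compound 4 (0.33 log units; beyond the scatter). For compound 4 the estimate is 150000 nM, with an expected range of 80000 nM to 300000 nM.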

Compound 4, half-maximal inhibitory concentration: > 100000 nM
Compound 4 gave a limit, no number (the forecaster's own chance of this, stated with the estimate: 75%); the middle value lies beyond the limit too.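

In this assay, going by these compounds alone, this is the first step at this position on a thiocarbonyl carbon, and pyrrolidin-1-yl in place of azepan-1-yl gives an at least 1.4-fold higher number from compound 3 to compound 4 (0.15 log units; that floor lies within the scatter). The value of compound 4 is a limit of the assay and not a number, so the size of this step is known only as a floor, and the steps linking compound 4 with compound 1 and compound 2 cannot be read. With compound 4, all three pyrrolidin-1-yl compounds sit at the same limit: the limit of > 100000 nM in this assay, at which 3 of the 4 values shown sit.

Going by these compounds, what piperidin-1-yl would read on this thiocarbonyl carbon remains open. So does the reading of azepan-1-yl with a decyl chain.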